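A Dimethylamino Swap in a Weak Series

This account rests on a few compounds, and the source may have more. Where it says the series, first, only, none or still open, it means among the compounds named here.

In a functional assay on MCF7 cells (Homo sapiens) for antiproliferative activity, read by MTT assay, with a stated time of 72 h (on this read-out higher numbers stand for weaker inhibition and lower numbers for stronger inhibition), three compounds have been tested so far. Compound 1 (`CCCSc1nc(N/N=C(\C)c2ccccc2O)c2nnn(Cc3ccc(Cl)cc3)c2n1`) gives 42600 nM, the only result among them that is a real number. Compound 2 (`CCCSc1nc(N/N=C/c2ccc(C)cc2)c2nnn(Cc3ccccc3)c2n1`) stands at > 64000 nM, which is a limit of the assay and not a number. Compound 3 (`CCCSc1nc(N/N=C/c2cc(OC)c(OC)c(OC)c2)c2nnn(Cc3ccccc3)c2n1`) reads > 64000 nM, and this too is a limit.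

The next compound to be measured, compound 4 (`CCCSc1nc(N/N=C/c2ccc(N(C)C)cc2)c2nnn(Cc3ccccc3)c2n1`), is compound 2 with a single change: dimethylamino in place of methyl on an aromatic carbon. Put simply, a 4-methylphenyl becomes a 4-(dimethylamino)phenyl, with dimethylamino in place of methyl on an aromatic carbon, para to a large group. Among the measured compounds shown here, no two measured compounds differ in only one place, so the data offer no direct guide to the size of such a change.

With no such guide, and with compound 2 at > 64000 nM, a limit, the safest expectation in this assay is no shift beyond the usual scatter, in either direction. The expected step is an at least 1.0-fold lower number from compound 2 to compound 4 (0.02 log units; that floor lies within the scatter), which is small. The result may well arrive as a limit again. For compound 4 the estimated value is 60000 nM, with an expected range from 30000 nM to 120000 nM.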

Compound 4, half-maximal inhibitory concentration: 12200 nM
For compound 4 the middle estimate is 4.9-fold (0.69 log units) above the measured one; measured number below the stated range.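

In this assay, among the compounds shown here, replacing methyl with dimethylamino on this aromatic carbon gives the first direct comparison, and it reads as an at least 5.2-fold lower number from compound 2 to compound 4 (0.71 log units; beyond the scatter). A change at this single place, turning a 4-methylphenyl into a 4-(dimethylamino)phenyl, is therefore enough to move the result beyond the usual scatter, and compound 4 has a real number where compound 2 has only a limit. The true size of the step stays unknown, and it can be stated only as a floor because compound 2 sits at a limit: the limit of > 64000 nM in this assay, at which 2 of the 4 values shown sit.

The compounds shown leave open whether a plain amino group, or an amine with longer chains such as diethylamino, would lower the number further or lose the step at this same place, and they do not reveal which feature of dimethylamino goes with the change. It also remains unclear whether the same swap would work on the other compounds, since compound 1 and compound 3 each differ from compound 4 in more than one place.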